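The source may hold more compounds than are shown below. What is called first, only, known or untested is meant among the compounds shown, and "the series" means these compounds.

Compound 1 `CC(C)Cc1ccc(C(C)c2nnc3sc(-c4ccc(Cl)cc4Cl)nn23)cc1`: 80.3%
Compound 2 `CC(C)Cc1ccc(C(C)c2nnc3sc(-c4ccccc4N)nn23)cc1`: 57.6%
Compound 3 `CC(C)Cc1ccc(C(C)c2nnc3sc(-c4ccc(N)cc4)nn23)cc1`: 78.8%

The three compounds share one core and differ only in the group carried on an aromatic carbon of that core. In a functional assay on the whole organism (strain Wistar albino) for inhibition, with Rattus norvegicus as the target, read by paw edema, with a stated time of 4 h, at a dose of 70 mg/kg by the oral route (on this read-out higher numbers stand for more inhibition at the one dose given (going by the name of the read-out) and lower numbers for less inhibition), compound 3 gives 78.8%, which places it second highest of the three numbers; its nearest neighbour is compound 1, a number 1.5 percentage points lower from compound 1 to compound 3 (within the scatter), and its furthest is compound 2, a number 21.2 percentage points higher from compound 2 to compound 3 (beyond the scatter).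

Compound 4 `CCCCNc1nn2c(C(C)c3ccc(CC(C)C)cc3)nnc2s1` has not yet been measured. It differs from compound 3 in one place: butylamino in place of 4-aminophenyl on an aromatic carbon. For the measured compounds named here, none of the measured steps exchanges a phenyl group for a group with no ring, so no step bears on this change directly. The steps that exist concern exchanges among substituted phenyl groups: a number 22.7 percentage points lower from compound 1 to compound 2 (beyond the scatter) and a number 1.5 percentage points lower from compound 1 to compound 3 (within the scatter) show that the group at this position can shift the read-out modestly or leave it within the scatter. Given that the ring itself is lost here, the account expects compound 4 to sit lower than compound 3, by about a number 13.8 percentage points lower from compound 3 to compound 4 (beyond the scatter), with a wide uncertainty. Compound 4 is therefore estimated at 65%, between 45% and 82%.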

Compound 4, a percentage reported as inhibition, in the whole organism at one dose (the size of the read-out at that dose, not a potency): 80.3%
Estimate against measurement, compound 4: 15.3 percentage points below; the range from low to high includes it.
By their numbers in this assay, from the lowest: compound 2; then compounds 3, 1 and 4 (each within the scatter of the next).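

In this assay, the aromatic ring on this carbon proves not to be required among these compounds: butylamino, which has no ring, replaces 4-aminophenyl with a number 1.5 percentage points higher from compound 3 to compound 4 (within the scatter), and it replaces 2,4-dichlorophenyl with no change at the digits printed from compound 1 to compound 4 (within the scatter). The earlier compounds shown here compared only substituted phenyl groups, whereas this result shows that an open butyl chain joined through its amino nitrogen can match the two better phenyl compounds within the scatter. Compound 2 goes against any simple reading that the group here hardly matters, as replacing its 2-aminophenyl with butylamino gives a number 22.7 percentage points higher from compound 2 to compound 4 (beyond the scatter), leaving it apart from the other three compounds by steps beyond the scatter.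

The compounds shown offer no measurement that accounts for these steps. Going by these compounds, it remains open whether a shorter chain such as methylamino, a longer chain such as octylamino, a branched isopropylamino group or an unsubstituted amine on this carbon would hold the same read-out, and whether compounds 1, 3 and 4 would still match at other doses.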